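The compounds below may be only part of what the source reports. "The series", "measured", "known", "first", "only" and "open" are said of these compounds alone.

Three compounds sharing one common core were tested in a functional assay on A549 cells (Homo sapiens) for antiproliferative activity, read by MTT assay, with a stated time of 48 h; on this read-out higher numbers stand for weaker inhibition and lower numbers for stronger inhibition. Compound 1 `CC(C)=CCC[C@]1(C)/C=C/[C@@H](OC(=O)C=C(C)C)[C@](C)(O)/C=C/C(=O)/C(CN(C)C)=C\C1` gives 590 nM, compound 2 `CC(C)=CCC[C@]1(C)/C=C/[C@@H](OC(=O)C=C(C)C)[C@](C)(O)/C=C/C(=O)/C(CN(C(C)C)C(C)C)=C\C1` gives 650 nM, and compound 3 `CC[Si](CC)(CC)C/C1=C/C[C@](C)(CCC=C(C)C)/C=C/[C@@H](OC(=O)C=C(C)C)[C@](C)(O)/C=C/C1=O` gives 3100 nM. Compound 3 stands highest of the three, weakest on this read-out. The next compound, compound 4 `CC(C)=CCC[C@]1(C)/C=C/[C@@H](OC(=O)C=C(C)C)[C@](C)(O)/C=C/C(=O)/C(C(=O)N2CCCC2)=C\C1`, differs from compound 3 in one place: a group of 7 heavy atoms (5 carbon, 1 nitrogen, 1 oxygen; one five-membered non-aromatic ring with 1 hetero atom) in place of a group of 8 heavy atoms (7 carbon, 1 silicon; no ring), on a double-bonded ring carbon. Going by the values given here, the steps that bear on this exchange are a 5.3-fold higher number from compound 1 to compound 3 (0.72 log units; beyond the scatter) and a 4.8-fold higher number from compound 2 to compound 3 (0.68 log units; beyond the scatter): both times replacing a nitrogen-bearing group with the silicon-bearing group raised the number modestly. Since compound 4 brings a nitrogen-containing group back, though as an amide rather than an amine, a modest drop is expected, a 3.1-fold lower number from compound 3 to compound 4 (0.49 log units; beyond the scatter). For compound 4 the estimate in this assay is 1000 nM, within a range from 300 nM to 3500 nM.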

Compound 4, half-maximal inhibitory concentration: 13000 nM
The estimate for compound 4 lay 13-fold (1.11 log units) below the measured number; measured number outside the range, above it.
By their numbers in this assay, from the lowest: compounds 1 and 2 (each within the scatter of the next); then compound 3; then compound 4.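

In this assay the (pyrrolidin-1-yl)carbonyl group makes compound 4 the weakest of the four, with a 4.2-fold higher number from compound 3 to compound 4 (0.62 log units; beyond the scatter) and larger steps in a 20-fold higher number from compound 2 to compound 4 (1.30 log units; beyond the scatter) and a 22-fold higher number from compound 1 to compound 4 (1.34 log units; beyond the scatter). A nitrogen in the group on this double-bonded ring carbon is therefore not enough to keep the number low, since this amide stands even above the silicon-bearing compound 3. No available data explain the gap between the amide and the two amines. Still open, on these data alone, is whether the carbonyl or the ring matters more; a (pyrrolidin-1-yl)methyl group, an amine carrying the same ring, would help separate the two.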